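The compounds below may be only part of what the source reports. "The series", "measured", "known", "first", "only" and "open" are said of these compounds alone.

Compounds measured so far in a functional assay on the whole organism for inhibition, with Nicotiana tabacum as the target; a higher number here means a weaker inhibitor, a lower number a stronger inhibitor:
compound 1 `Cc1nc(Nc2ccc(F)cc2)c2cc[nH]c2n1` — 372000000 nM
compound 2 `Cc1ccc(Nc2[nH]c(C)nc3nccc2-3)cc1` — 759000000 nM
compound 3 `Cc1nc(Nc2ccc(O)cc2)c2cc[nH]c2n1` — 155000000 nM

Compound 2 gives the highest number of the three in this assay and is therefore the weakest inhibitor of the set; compound 1 sits nearest to it and compound 3 furthest, both gaps beyond the scatter. Going by the values given here, the only single-point step among the measured compounds is the one from compound 1 to compound 3, a 2.4-fold lower number from compound 1 to compound 3 (0.38 log units; beyond the scatter), which puts hydroxy in place of fluoro on an aromatic carbon and is modest in size.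

Compound 4 `Cc1nc2nccc-2c(Nc2ccc(C(C)C)cc2)[nH]1` remains to be measured. It differs from compound 2 by isopropyl in place of methyl on an aromatic carbon, para to a large group. Among the compounds with values here, no measured step exchanges one alkyl group for another on that ring, so the hydroxy-for-fluoro step gives no direct guide; it shows only that a change of substituent on this ring moved the number modestly. With nothing pointing either way, the expectation is a step that need not exceed the scatter: a 1.1-fold lower number from compound 2 to compound 4 (0.04 log units; within the scatter). The estimate for compound 4 in this assay is 700000000 nM, within a range of 250000000 nM to 2000000000 nM.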

Compound 4, half-maximal inhibitory concentration: 45700000 nM
For compound 4 the middle estimate is 15-fold (1.19 log units) above the measured one, outside the stated range (below it).
By their numbers in this assay, from the lowest: compound 4; then compound 3; then compound 1; then compound 2.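

In this assay, going by these compounds alone, the position para to a large group proves far more responsive than the earlier compounds indicated: isopropyl in place of methyl on an aromatic carbon gives a 17-fold lower number from compound 2 to compound 4 (1.22 log units; beyond the scatter) and makes this the large step. Within the data shown here, the only earlier single-point step, a 2.4-fold lower number from compound 1 to compound 3 (0.38 log units; beyond the scatter), was modest and involved a different exchange, so it gave no sign that a change between two alkyl groups on this ring could move the number this far. The result also shows that a group with 3 heavy atoms is tolerated here and gives a stronger inhibitor than methyl in compound 2, although nothing available explains why the number drops so sharply.

On these data alone, with only methyl and isopropyl compared directly, it remains open whether the number keeps falling with tert-butyl or a longer chain at this position, or whether the gain belongs to isopropyl alone. Also open, as far as these compounds go, is how an amine or a carboxylic acid placed here would compare with isopropyl in compound 4.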